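A few compounds are considered here, and "the series" means these few. Any claim that something is new, unique, unknown or untested is made for them only; others in the source may bear on it.

Notes on the series around the shared core of compound 1 `Cc1cc(NCc2nccs2)n2nc(C)c(-c3ccccc3)c2n1`, read in a physicochemical assay for solubility, read by HPLC, using the shake flask method, measured as kinetic solubility, with a stated time of 2 h, at pH 7.4; on this read-out higher numbers stand for higher solubility and lower numbers for lower solubility. Compound 1 gives 108000 nM. Compound 2 `Cc1cc(NCc2ccc3ccccc3n2)n2nc(C)c(-c3ccccc3)c2n1` returns only a limit of the assay, reported as < 5000 nM. Compound 3 `Cc1cc(NCc2ccccn2)n2ncc(-c3ccc(F)c(Cl)c3)c2n1` likewise returns only a limit, reported as < 5000 nM. On the numbers shown, compound 3 therefore stands at the floor of what this assay resolves, and it shares that position with compound 2: two of the three values sit at the limit of < 5000 nM in this assay, at which 2 of the 3 values shown sit, with only compound 1 giving a number. Among the compounds with values here, no step between measured compounds that differ in a single place is available in this set, so no measured size of change can be quoted.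

Compound 4 `Cc1cc(NCc2ccccn2)n2ncc(C3=CCOCC3)c2n1` is the next entry, still to be measured in this assay. It differs from compound 3 at one place: a group of 6 heavy atoms (5 carbon, 1 oxygen; one six-membered non-aromatic ring with 1 hetero atom) in place of a group of 8 heavy atoms (6 carbon, 1 fluorine, 1 chlorine; one six-membered aromatic ring of carbon only), on an aromatic carbon. With compound 3 at a limit, any rise will register as a step of unknown starting size. The expectation is a move upward rather than none beyond the scatter, with compound 4 estimated to give 30000 nM, in a range from 5000 nM to 150000 nM, which corresponds to an expected step of an at least 6.0-fold higher number from compound 3 to compound 4 (0.77 log units; beyond the scatter).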

Compound 4, solubility: 171000 nM
For compound 4 the middle estimate is 5.7-fold (0.76 log units) below the measured one, outside the stated range (above it).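

In this assay, the position on the five-membered aromatic ring with 2 nitrogen now has its first measured change between compounds that differ in one place: 3-chloro-4-fluorophenyl gives way to a six-membered non-aromatic ring with 1 hetero atom, with an at least 34-fold higher number from compound 3 to compound 4 (1.53 log units; beyond the scatter). The entering group has 1 double bond outside aromatic rings and 1 hydrogen-bond acceptor, and this single exchange is enough to take the read-out from the assay floor to a measured number, so this position clearly has a strong bearing on the read-out. The value of compound 3 is a limit and not a number, so the step gives only a minimum size and its full size stays unknown: the limit of < 5000 nM in this assay, at which 2 of the 4 values shown sit.

Still open, from the compounds shown here alone, is which part of the exchange goes with the step, whether the ring oxygen, the loss of chlorine and fluorine, or the loss of the aromatic ring; a cyclohexenyl group or a morpholine at this position would help separate these. Also open, going by these compounds, is whether a step of this size would carry over to compounds that differ from compound 4 elsewhere on the shared core.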